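Phenyl for Methyl on a Chain Showing No Inhibition

This account rests on a few compounds, and the source may have more. Where it says the series, first, only, none or still open, it means among the compounds named here.

Compound 1 `C=CCn1ncc2c(C)nc(CC)n2c1=O` was tested in a functional assay for inhibition, with Homo sapiens as the target; on this read-out lower numbers stand for stronger inhibition and higher numbers for weaker inhibition. Compound 1 reaches only the limit of that assay, > 48000 nM, so no number is known for it. Compound 2 `CCCc1ncn2c(O)nncc12` likewise gives only a limit in this assay, > 48000 nM. Compound 3 `c1ncn2c1C(NC1CCCC1)NN=C2NC1CCCC1` also stops at a limit, > 48000 nM. Among the compounds with values here, all three values sit at the limit of > 48000 nM in this assay, at which 3 of the 3 values shown sit, so no step between measured compounds can be sized and compound 1 cannot be placed relative to the others. Compound 4 `C=CCn1ncc2c(C)nc(Cc3ccccc3)n2c1=O` carries phenyl in place of methyl on a saturated chain carbon bound to an aromatic carbon; cut one bond further out, the same difference reads ethyl to benzyl. With every measured value a limit, the step that the limit leaves unreadable from compound 1 to compound 4 is expected to be none beyond the scatter. Compound 4 is estimated at 60000 nM, between 20000 nM and 200000 nM.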

Compound 4, half-maximal inhibitory concentration: > 48000 nM
Compound 4: only a limit was reported; the forecaster's own chance of this, stated with the estimate: 80%; the middle value is on the limit's open side.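

Within the data shown here, compound 1 and compound 4 both stop at a limit in this assay, not at a number, so no step between them can be read: the limit of > 48000 nM in this assay, at which 4 of the 4 values shown sit. The compounds shown leave open whether phenyl in place of methyl changes inhibition at all.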